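The source may report more compounds than this note shows. Statements on the series, on what has been measured and on what is new or still open speak of the compounds shown alone.

Measured so far in an assay on isolated protein for inhibition of N-lysine methyltransferase SMYD2 (Homo sapiens), read by filter binding, with a stated time of 1 h; a higher number here means a weaker inhibitor, a lower number a stronger inhibitor: compound 1 `CC(C)N1C(=O)C(Cc2ccccc2CS(=O)(=O)c2ccccc2)COC12C=CC(=O)C=C2` gives > 20000 nM, a limit of the assay. Compound 2 `CN1C(=O)C(CCNc2cccnc2)COC12C=CC(=O)C=C2` gives > 20000 nM, also a limit. Compound 3 `CN1C(=O)C(CCNc2ccc(Cl)c(Cl)c2)COC12C=CC(=O)C=C2` gives 3820 nM.

Compound 2 thus stands at the limit, where the limit of > 20000 nM in this assay, at which 2 of the 3 values shown sit, also sits; no number below it is known for compound 2. Compound 4 `CN1C(=O)C(CCO[Si](C)(C)C(C)(C)C)COC12C=CC(=O)C=C2` differs from compound 2 by a group of 8 heavy atoms (6 carbon, 1 oxygen, 1 silicon; no ring) in place of a group of 7 heavy atoms (5 carbon, 2 nitrogen; one six-membered aromatic ring with 1 hetero atom), on a saturated chain carbon, two bonds along the chain from a saturated ring carbon. Among the compounds with values here, the only measured step from compound 2 is an at least 5.2-fold lower number from compound 2 to compound 3 (0.71 log units; beyond the scatter), in which another six-membered aromatic ring entered on the amine nitrogen; the group entering in compound 4 has no ring and no amine, so that step does not cover it. Within the data shown here, with no step of this kind measured, compound 4 is expected to remain near the limit in this assay, estimated at 20000 nM (range 5000 nM to 60000 nM), an expected step of a number no higher from compound 2 to compound 4 (the limit leaves the size open).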

Compound 4, half-maximal inhibitory concentration: > 30000 nM
Compound 4 gave a limit, no number; the forecaster's own chance of this, stated with the estimate: 70%; at least 1.5-fold (0.17 log units) between middle value and limit.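

Within the data shown here, compound 2 and compound 4 both give only limits, so no step between them can be read. The compounds shown leave open whether the true number for compound 4 lies higher or lower than that for compound 2.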